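This account rests on a few compounds, and the source may have more. Where it says the series, first, only, none or still open, it means among the compounds named here.

Of the compounds shown here, three with a shared core have been measured in a functional assay on HEK293 cells for antagonist activity at metabotropic glutamate receptor 5 (Homo sapiens), read by FLIPR and calcium flux; on this read-out lower numbers stand for stronger inhibition and higher numbers for weaker inhibition. Compound 1 `O=C(N[C@H]1CCC[C@H](NC(=O)c2cnccn2)C1)c1cccc(Cl)c1` gives 1370 nM in this assay, the highest of the three numbers. Compound 3 `Cc1cccc(C(=O)N[C@H]2CCC[C@H](NC(=O)c3ccccn3)C2)c1` gives 1000 nM, a number that lies within the usual scatter of compound 1, so the two cannot be told apart on this read-out. Compound 2 `N#Cc1cccc(C(=O)N[C@@H]2CCC[C@@H](NC(=O)c3ccccn3)C2)c1` gives 231 nM, a number clearly lower than that of compound 1 and beyond the scatter.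

The next compound to be measured is compound 4 `O=C(N[C@H]1CCC[C@H](NC(=O)c2ccccc2F)C1)c1cccc(Cl)c1`. It differs from compound 1 in one place: 2-fluorophenyl in place of pyrazin-2-yl on a carbonyl carbon. Going by the values given here, no pair of measured compounds shows this particular exchange, so there is no measured step to lean on; the three values shown involve other changes on the core.

With nothing directly comparable, the expectation for compound 4 is a step of a 1.4-fold lower number from compound 1 to compound 4 (0.14 log units; within the scatter), which could fall on either side of the number for compound 1 and may well stay within the scatter. On that basis compound 4 is estimated to give about 1000 nM in this assay, with a plausible range from 300 nM to 3500 nM.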

Compound 4, half-maximal inhibitory concentration: 175 nM
Estimate against measurement, compound 4: 5.7-fold (0.76 log units) above; measured number below the stated range.
By their numbers in this assay, from the lowest: compounds 4 and 2 (each within the scatter of the next); then compounds 3 and 1 (each within the scatter of the next).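

In this assay, the group on this carbonyl carbon turns out to matter: with the rest of the structure unchanged, 2-fluorophenyl in place of pyrazin-2-yl gives a 7.8-fold lower number from compound 1 to compound 4 (0.89 log units; beyond the scatter). Going by these compounds alone, the earlier compounds could not show this, as no two of them differed in only one place, so this is the first single change whose size can be read. The exchange replaces a ring with 2 hetero atoms and 2 hydrogen-bond acceptors with a carbon-only ring bearing a fluorine and having 0 hydrogen-bond acceptors, but nothing measured here explains the shift in the number.

This single step changes the ring atoms and adds the fluorine together, so it cannot tell which of the two accounts for the lower number. A plain phenyl group at this place would help to separate those two changes, and a cyclohexyl group would show whether an aromatic ring is needed on this carbonyl carbon at all.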